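The source may report more compounds than this note shows. Statements on the series, on what has been measured and on what is new or still open speak of the compounds shown alone.

The set holds three measured compounds and one still awaiting measurement. Compound 1 `Cc1ccc2nc(/N=C3\C(=O)N(CN(c4ccccc4)c4ccccc4)c4cccc(Cl)c43)sc2c1` gives 85000 nM in a functional assay on MDA-MB-468 cells (Homo sapiens) for cytotoxicity, read by sulforhodamine B assay, with a stated time of 48 h; on this read-out higher numbers stand for weaker inhibition of growth and lower numbers for stronger inhibition of growth. Compound 2 `CCN(CC)CN1C(=O)C(=O)c2c(Br)cccc21` gives 11700 nM in this assay. Compound 3 `O=C1C(=O)N(CN(c2ccccc2)c2ccccc2)c2cccc(Br)c21` gives 63300 nM in this assay. Among the three numbers, compound 3 holds the second highest; its nearest neighbour is compound 1, whose number lies within the scatter of it, while its furthest is compound 2, whose lower number lies beyond the scatter.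

Compound 4 `O=C1C(=O)N(CN(c2ccccc2)c2ccccc2)c2ccccc21` has not yet been measured in this assay. It is related to compound 3 by a single change: hydrogen in place of bromo on an aromatic carbon. Within the data shown here, no step between two measured compounds of this kind has been recorded, so the size of this step cannot be read from a measured pair and rests on expectation alone. The expectation is a step from compound 3 to compound 4 of a 1.3-fold higher number from compound 3 to compound 4 (0.10 log units; within the scatter), which is not beyond the scatter, because compound 3 gives 63300 nM and shares almost all of its structure with compound 4. Compound 4 is therefore expected to give about 80000 nM in this assay, with a range from 30000 nM to 200000 nM.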

Compound 4, concentration for 50% growth inhibition: 21500 nM
For compound 4 the middle estimate is 3.7-fold (0.57 log units) above the measured one, and the stated range ends above it.
By their numbers in this assay, from the lowest: compounds 2 and 4 (each within the scatter of the next); then compounds 3 and 1 (each within the scatter of the next).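

In this assay, hydrogen in place of bromo on an aromatic carbon, ortho to a fused ring and meta to a fused ring, gives a 2.9-fold lower number from compound 3 to compound 4 (0.47 log units; beyond the scatter) and so supplies the first measured size for a single change in this set. The step lies beyond the usual scatter and points toward stronger inhibition of growth, which shows that bromo at this position is not needed for the growth inhibition of compound 3 and that the compound without it inhibits growth more strongly. Nothing measured here explains why this change lowers the number.

This single pair does not show how another group on the same aromatic carbon, such as a methoxy group or an amine, would compare with bromo or hydrogen. It also leaves open whether removing the halogen would produce a step of similar size and direction on the core of compound 1 or compound 2, where the groups elsewhere in the structure differ.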